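This account rests on a few compounds, and the source may have more. Where it says the series, first, only, none or still open, it means among the compounds named here.

Measured compounds in an assay on isolated protein for inhibition of bone morphogenetic protein 1 (Homo sapiens); a lower number here means a stronger inhibitor, a higher number a weaker inhibitor:
Compound 1, `COc1ccc(S(=O)(=O)N(Cc2cc(C)on2)[C@H](C)C(=O)NO)cc1`: 230 nM
Compound 2, `COc1ccc(S(=O)(=O)N(Cc2sc3scc(C)c3c2C)[C@H](C)C(=O)NO)cc1`: 60 nM
Compound 3, `COc1ccc(S(=O)(=O)N(Cc2cccc3ccccc23)[C@H](C)C(=O)NO)cc1`: 90 nM

Among these three, compound 1 stands highest in this assay; compound 3 lies nearest to it and compound 2 furthest, and both gaps are beyond the usual scatter. Compound 4, `COc1ccc(S(=O)(=O)N(Cc2cnc(Cl)s2)[C@H](C)C(=O)NO)cc1`, has not yet been measured. It differs from compound 1 by 2-chloro-1,3-thiazol-5-yl in place of 5-methyl-1,2-oxazol-3-yl on a saturated chain carbon bound to a sulfonamide nitrogen. For the measured compounds named here, no measured pair shows an exchange of this kind, and the three measured compounds give no guide to how one five-membered ring with the same heavy-atom count replaces another. The step from compound 1 is therefore expected to be small and without a clear direction, a 1.2-fold lower number from compound 1 to compound 4 (0.06 log units; within the scatter). Compound 4 is estimated at 200 nM, with a range from 80 nM to 500 nM.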

Compound 4, half-maximal inhibitory concentration: 180 nM
Estimate against measurement, compound 4: 1.1-fold (0.05 log units) above; the range from low to high includes it.
By their numbers in this assay, from the lowest: compounds 2, 3, 4 and 1 (each within the scatter of the next, the first and the last beyond it).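

In this assay, 2-chloro-1,3-thiazol-5-yl in place of 5-methyl-1,2-oxazol-3-yl on a saturated chain carbon bound to a sulfonamide nitrogen gives a 1.3-fold lower number from compound 1 to compound 4 (0.11 log units; within the scatter). This step shows that, at this place, one five-membered aromatic ring with 2 hetero atoms can replace another of the same heavy-atom count while the two compounds stay within the scatter of each other. Nothing available bears on the reason for this result.

Left open is what the chlorine contributes, and how the same ring carrying an amine or a carboxylic acid in its place would read in this assay.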